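The source may hold more compounds than are shown below. What is called first, only, known or untested is meant among the compounds shown, and "the series" means these compounds.

Two piperidine amides, each carrying a long chain, have been tested in a functional assay on PANC-1 cells (Homo sapiens) for cytotoxicity, read by WST assay, with a stated time of 24 h; a lower number here means a stronger inhibitor, a higher number a weaker inhibitor. Compound 1 `O=C(/C=C/CCCCC#Cc1ccccc1)N1CCCCC1` gives > 100000 nM, which is a limit of the assay and not a number. Compound 2 `O=C(CCCCCCCCc1ccc(O)cc1)N1CCCCC1` gives > 100000 nM, which is also a limit. Compound 2 therefore has no exact position on the scale, and the data so far amount to one point: the limit of > 100000 nM in this assay, at which 2 of the 2 values shown sit. For the measured compounds named here, no step between measured compounds is available to gauge how much a single change can shift the result in this assay.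

Compound 3 `O=C(CCCCCCCCC1CCCCC1)N1CCCCC1` departs from compound 2 at one place, with cyclohexyl in place of 4-hydroxyphenyl on a saturated chain carbon, eight bonds along the chain from a carbonyl carbon. With nothing but limits to go on, no step beyond the scatter is expected, in either direction, and a further limit is the likeliest outcome. The expected change is a number no higher from compound 2 to compound 3 (the limit leaves the size open). For compound 3 the estimated value is 100000 nM, with an expected range of 50000 nM to 200000 nM.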

Compound 3, half-maximal inhibitory concentration: > 100000 nM
Compound 3 ended at the assay's limit (the forecaster's own chance of this, stated with the estimate: 75%); the middle value sits exactly at the limit.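

In this assay compound 3 gives > 100000 nM, which is a limit of the assay and not a number. For the compounds shown here, compound 2 also stands at a limit, so no step from it to compound 3 can be read. The compounds shown leave open which change, if any, would give a measurable value, as the data still amount to one point: the limit of > 100000 nM in this assay, at which 3 of the 3 values shown sit.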